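The compounds below may be only part of what the source reports. "The series", "measured", "known", "first", "only" and "open" are said of these compounds alone.

Compound 2 `COc1cc(C)cc(-c2nn(CC#N)cc2-c2ccnc(-c3ccc(N(C)C)cc3)c2)c1` stands lowest of the two numbers recorded so far in a functional assay on MCF7 cells (Homo sapiens) for inhibition, read by sulforhodamine B assay, with a stated time of 48 h (a lower number here means a stronger inhibitor of growth, a higher number a weaker inhibitor of growth), where compound 2 gives 66.4 nM. Its only measured companion, compound 1 `Cc1cc(O)cc(-c2nn(CC#N)cc2-c2ccnc(-c3ccc(Oc4ccccc4)cc3)c2)c1`, differs from it in two places at once, and in this assay compound 1 gives 2230 nM, a gap well beyond the scatter. Compound 3 `Cc1cc(O)cc(-c2nn(CC#N)cc2-c2ccnc(-c3ccc(N(C)C)cc3)c2)c1` has not yet been measured. It differs from compound 2 in a single place: hydrogen in place of methyl on an oxygen on an aromatic ring, the same change read one bond further out being methoxy to hydroxy. For the measured compounds named here, no step between measured compounds that differ in only this place exists, so the direction of the change rests on judgement alone. A small loss of potency is expected, with the step estimated at a 1.8-fold higher number from compound 2 to compound 3 (0.26 log units; within the scatter). Compound 3 is accordingly expected to give about 120 nM in this assay, within a range from 30 nM to 500 nM.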

Compound 3, concentration for 50% growth inhibition: 975 nM
Compound 3: middle estimate off by 8.1-fold (0.91 log units), on the low side; measured number outside the range, above it.
By their numbers in this assay, from the lowest: compound 2; then compound 3; then compound 1.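

In this assay, the methyl on the oxygen on the aromatic ring proves to matter a great deal: with the dimethylamino group held constant, methoxy to hydroxy gives a 15-fold higher number from compound 2 to compound 3 (1.17 log units; beyond the scatter). With the 3-hydroxy-5-methylphenyl group held constant, dimethylamino in place of phenoxy on an aromatic carbon gives a 2.3-fold lower number from compound 1 to compound 3 (0.36 log units; beyond the scatter), so the change at the oxygen is the larger of the two single steps now available. Nothing in the information at hand explains why removing the methyl has this effect.

The compounds shown leave open whether methoxy to hydroxy carries the same size of step when phenoxy replaces dimethylamino. They also leave open how a longer chain on that oxygen, such as ethyl, or an amine in place of the methoxy would compare.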